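Aniline halogen swap in a thienopyridinone carboxamide series

The compounds below may be only part of what the source reports. "The series", "measured", "known", "first", "only" and "open" are said of these compounds alone.

Measured compounds:
- compound 1, `CCOC(=O)c1c(Nc2ccc(I)cc2F)sc2c1CC(C)(C)CNC2=O`: "not determined" (no result reported) in a functional assay on HT-29 cells (Homo sapiens) for antiproliferative activity; a lower number here means a stronger inhibitor, a higher number a weaker inhibitor
- compound 2, `CC1(C)CNC(=O)c2sc(Nc3ccc(I)cc3F)c(C(=O)NC[C@H]3CCCN3)c2C1`: 120 nM
- compound 3, `CC1(C)CNC(=O)c2sc(Nc3ccc(I)cc3Cl)c(C(N)=O)c2C1`: 596 nM

Compound 1 carries an ester on the shared core and shows "not determined" (no result reported) in this assay. Compound 2, with a pyrrolidinylmethyl amide, gives 120 nM and is the stronger of the two numbers in hand. Compound 3, with the primary carboxamide and the 2-chloro-4-iodophenyl group, gives 596 nM and stands at the higher of the two numbers; its gap to compound 2 lies beyond the scatter. The two compounds differ in more than one place, so the pair does not isolate either change.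

Compound 4, `CC1(C)CNC(=O)c2sc(Nc3ccc(I)cc3F)c(C(N)=O)c2C1`, keeps the primary carboxamide of compound 3 and differs only at the aniline: fluoro in place of chloro on an aromatic carbon. Among the compounds with values here, the resulting 2-fluoro-4-iodophenyl group is the one present in compound 2, but no single-change pair anchors this swap. The step from compound 3 is therefore expected to be small, if anything a modest decrease in the number, and quite possibly within the scatter: a 1.5-fold lower number from compound 3 to compound 4 (0.17 log units; within the scatter). On that basis compound 4 is estimated at 400 nM in this assay, with a likely range from 130 nM to 1200 nM.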

Compound 4, half-maximal inhibitory concentration: 158 nM
Compound 4: the middle estimate sits 2.5-fold (0.40 log units) above what was measured, and the stated range covers the measured number.
By their numbers in this assay, from the lowest: compounds 2 and 4 (each within the scatter of the next); then compound 3.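

The halogen on the aniline ring now has a single-change pair behind it: in this assay, fluoro in place of chloro, on an aromatic carbon ortho to a large group, gives a 3.8-fold lower number from compound 3 to compound 4 (0.58 log units; beyond the scatter), so this position responds to the identity of the halogen. The amide nitrogen behaves differently, since hydrogen in place of (pyrrolidin-2-yl)methyl gives a 1.3-fold higher number from compound 2 to compound 4 (0.12 log units; within the scatter), and of the two single changes only the halogen swap moves the number beyond the scatter in this assay. Nothing at hand gives a reason for the size of either step.

Compound 1 stands at "not determined" (no result reported), so any step to it cannot be read, and the ester on the shared core remains uncharacterised in this assay. Still open, from the compounds shown here alone, are whether the halogen step carries over to the (pyrrolidin-2-yl)methyl amide, how a methyl group or a hydrogen at the same aromatic carbon would compare with fluoro and chloro, and whether a longer chain ending in a dimethylamino group or a carboxylic acid on the amide nitrogen would also stay within the scatter of the primary carboxamide.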